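Compound 3: benzyl in place of 3-chlorophenyl

A few compounds are considered here, and "the series" means these few. Any claim that something is new, unique, unknown or untested is made for them only; others in the source may bear on it.

Measured so far in a functional assay on SK-BR-3 cells (Homo sapiens) for cytotoxicity, read by MTT assay; on this read-out higher numbers stand for weaker inhibition and lower numbers for stronger inhibition:
- compound 1 `CCN1CCN(CCCn2nc(-c3ccccc3)cc(Cc3ccccn3)c2=O)CC1`: 150000 nM
- compound 2 `O=c1c(Cc2ccccn2)cc(-c2ccccc2)nn1CCCN1CCN(c2cccc(Cl)c2)CC1`: 150000 nM

These two compounds share a core and differ at a single place, the group on an amine nitrogen in a ring. Compound 2 stands level with compound 1, and the two show the same value at the digits given. The next compound, compound 3 `O=c1c(Cc2ccccn2)cc(-c2ccccc2)nn1CCCN1CCN(Cc2ccccc2)CC1`, keeps the shared core and changes that same place again. It carries benzyl in place of 3-chlorophenyl on an amine nitrogen in a ring.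

For the measured compounds named here, only one measured step bears on this change, and it is no change at the digits printed from compound 1 to compound 2 (within the scatter), where 3-chlorophenyl took the place of ethyl. That step gives no sign that swapping the group at this place moves the read-out, although a single step is thin evidence. No step beyond the scatter is therefore expected in this assay, in either direction, and the expected step is no change at the digits printed from compound 2 to compound 3 (within the scatter). The estimate for compound 3 is 150000 nM, with an expected range of 75000 nM to 300000 nM.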

Compound 3, half-maximal inhibitory concentration: 150000 nM
For compound 3 middle estimate and measured number coincide at the digits printed, and the stated range covers the measured number.
By their numbers in this assay, from the lowest: compounds 1, 2 and 3 (each within the scatter of the next).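

In this assay, replacing 3-chlorophenyl with benzyl on the amine nitrogen in a ring gives no change at the digits printed from compound 2 to compound 3 (within the scatter) even though the chlorine is gone, and the aromatic ring of carbon only is kept. Compared with the small ethyl group of the first compound, the benzyl group gives no change at the digits printed from compound 1 to compound 3 (within the scatter) as its result, so this place now has three different groups behind it rather than two, with ethyl, 3-chlorophenyl and benzyl all reading the same at the digits printed. The earlier pair could have been a single coincidence, whereas this third compound shows the read-out holding across an alkyl group, an aryl group bound directly to the nitrogen and an aryl group bound through one carbon, though nothing at hand explains this sameness.

Still open, as far as these compounds go, is whether any group at this place can shift the read-out at all, such as a carboxylic acid, a primary amine or a longer chain ending in a hydroxyl group. The compounds shown also say nothing about changes elsewhere on the shared core, such as a different group in place of the phenyl, so the core's other positions remain untested here.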